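A Second Fluorine on the Aminomethyl Side Chain

The source may report more compounds than this note shows. Statements on the series, on what has been measured and on what is new or still open speak of the compounds shown alone.

Compound 2 `CCN(Cc1nc2cc(C(F)(F)F)ccc2nc1-c1ccccc1)c1ccc(F)cc1` gives 3000 nM in an assay on isolated protein for inhibition of Dihydrofolate reductase (Homo sapiens), read by spectrophotometry (a higher number here means a weaker inhibitor, a lower number a stronger inhibitor), the lower of two numbers, while compound 1 `CN(Cc1nc2cc(C(F)(F)F)ccc2nc1-c1ccccc1)c1ccc(Cl)cc1` gives 5000 nM; the step of a 1.7-fold lower number from compound 1 to compound 2 (0.22 log units; within the scatter) separates them. Compound 3 `CCN(Cc1nc2cc(C(F)(F)F)ccc2nc1-c1ccccc1)c1ccc(F)c(F)c1` differs from compound 2 by fluoro in place of hydrogen on an aromatic carbon. Going by the values given here, no measured step adds a fluoro to this ring, and the one step known changes two groups at once and stays within the scatter. Compound 3 is therefore expected to show no change at the digits printed from compound 2 to compound 3 (within the scatter). Compound 3 is therefore estimated at 3000 nM, within 1200 nM to 7500 nM.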

Compound 3, inhibition constant: 5000 nM
The estimate for compound 3 lay 1.7-fold (0.22 log units) below the measured number; low and high end bracket the measured number.
By their numbers in this assay, from the lowest: compounds 2, 1 and 3 (each within the scatter of the next).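

Going from 4-fluorophenyl to 3,4-difluorophenyl is the first step here that alters one place only, and in this assay it gives a 1.7-fold higher number from compound 2 to compound 3 (0.22 log units; within the scatter). This position, ortho to a fluoro group, therefore takes a second fluoro with no difference that can be told apart from repeat measurements. Nothing at hand explains this result.

As far as these compounds go, whether a chloro, a methoxy or an amine at this same position would also stay within the scatter remains open. So does the effect of a longer chain on the side-chain nitrogen.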